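The compounds below may be only part of what the source reports. "The series", "measured", "known", "first", "only" and "open" are said of these compounds alone.

In a functional assay on the whole organism (Abdomen) with Mus musculus as the target (a lower number here means that less compound is needed, a higher number that more compound is needed for the effect), compound 2 (`CCc1nc(Cc2c[nH]cn2)sc1CC`) gives > 30 mg/kg, and this value is a limit of the assay, not a number. Compound 1 (`CCc1sc(Cc2c[nH]cn2)nc1C`) gives 2.8 mg/kg in this assay. Compound 3 (`CCc1cnc(Cc2c[nH]cn2)s1`) takes away one of the two ethyl groups of compound 2, the one next to the ring nitrogen: hydrogen in place of ethyl on an aromatic carbon. Within the data shown here, only one measured change bears on this group. Compound 1 carries a methyl where compound 2 carries this ethyl. That change, methyl in place of hydrogen on a saturated chain carbon bound to an aromatic carbon, is large: an at least 10-fold higher number from compound 1 to compound 2 (1.02 log units; beyond the scatter). Removing the ethyl altogether is therefore expected to lower the number in this assay, although hydrogen at this place has not been measured and one step is thin support. The expected change is an at least 5.0-fold lower number from compound 2 to compound 3 (0.69 log units; beyond the scatter). Compound 3 is estimated at 6 mg/kg, with an expected range of 1.5 mg/kg to 30 mg/kg.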

Compound 3, dose for half-maximal effect: > 30 mg/kg
Compound 3 gave a limit, no number (the forecaster's own chance of this, stated with the estimate: 15%); at least 5.0-fold (0.69 log units) between middle value and limit.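

In this assay, hydrogen in place of methyl on the aromatic carbon next to the ring nitrogen gives an at least 10-fold higher number from compound 1 to compound 3 (1.02 log units; beyond the scatter), so this position does not simply tolerate a smaller group. Of the three groups seen here, ethyl, methyl and hydrogen, only the methyl of compound 1 gives a readable number, 2.8 mg/kg. The step from compound 2 to compound 3 cannot be read, as both values are limits of the assay and not numbers: the limit of > 30 mg/kg in this assay, at which 2 of the 3 values shown sit.

Going by these compounds, how far either limit lies from a true value stays open, as does whether methyl alone serves at this position or a chlorine atom or a methoxy group would serve as well. On these data alone, the ethyl on the neighbouring ring atom is common to all three compounds, so what an amine or a longer chain would do there also remains open.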